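Cyclohexyl for methoxyphenyl at the chain end

The compounds below may be only part of what the source reports. "The series", "measured", "known", "first", "only" and "open" are said of these compounds alone.

Compound 1 `COc1ccc(OCCCCCCN2C[C@H](O)[C@@H](O)[C@H](O)[C@H]2CO)cc1` has been measured in an ADME assay on MDBK cells (Bos taurus) for cytotoxicity, read by MTT assay; a lower number here means that less compound is tolerated, a higher number that more compound is tolerated. In this assay compound 1 gives > 500000 nM, which is a limit of the assay and not a number. Compound 2 `OC[C@@H]1[C@@H](O)[C@H](O)[C@@H](O)CN1CCCCCCOc1ccc(OC(F)(F)F)cc1` likewise gives only the limit > 500000 nM in this assay. Compound 3 `OC[C@@H]1[C@@H](O)[C@H](O)[C@@H](O)CN1CCCCCCOc1cccc(C(F)(F)F)c1` also gives only the limit > 500000 nM in this assay. Compound 1 therefore stands where every value shown stands, namely at the limit of > 500000 nM in this assay, at which 3 of the 3 values shown sit, and no order among the three can be read. Among the measured compounds shown here, the single step with both ends measured, a step that the two limits leave unreadable from compound 1 to compound 2, cannot be sized because both of its ends sit at the limit of > 500000 nM in this assay, at which 3 of the 3 values shown sit.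

Compound 4 `CCC1CCC(OCCCCCCN2C[C@H](O)[C@@H](O)[C@H](O)[C@H]2CO)CC1` is not yet measured. It differs from compound 1 by 4-ethylcyclohexyl in place of 4-methoxyphenyl on an oxygen on a saturated carbon. For the measured compounds named here, no measured step bears on this change in a readable way; the step from compound 1 to compound 2 is the only one and its size is hidden by the limits. Nothing in the shown values suggests that compound 4 will move off the limit, so the expected step in this assay, a number no higher from compound 1 to compound 4 (the limit leaves the size open), is none beyond the scatter. Compound 4 is estimated at 500000 nM in this assay, with an expected range from 250000 nM to 1000000 nM.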

Compound 4, half-maximal cytotoxic concentration: > 500000 nM
Compound 4: no number, only a limit; the forecaster's own chance of this, stated with the estimate: 85%; the middle value sits exactly at the limit.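

No step can be read between compound 1 and compound 4, which share one assay limit rather than numbers: the limit of > 500000 nM in this assay, at which 4 of the 4 values shown sit. The compounds shown leave open whether any change at the chain end brings a value off this limit in this assay.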